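A few compounds are considered here, and "the series" means these few. Any claim that something is new, unique, unknown or untested is made for them only; others in the source may bear on it.

Of the compounds shown here, three with a shared core have been tested in a functional assay on A-375 cells (Homo sapiens) for inhibition, read by MTT assay, with a stated time of 48 h; on this read-out higher numbers stand for weaker inhibition and lower numbers for stronger inhibition. Compound 1 `CCO[C@H]1C=C[C@H]2C/C=C\C[C@H](c3ccc(Cl)cc3)OC(=O)C[C@@H]1O2` gives 4900 nM and compound 2 `COc1ccc(CO[C@H]2C=C[C@H]3C/C=C\C[C@H](c4ccc(F)cc4)OC(=O)C[C@@H]2O3)cc1` gives 4760 nM, so these two values stand level within the usual scatter. Compound 3 `COc1ccc(CO[C@H]2C=C[C@H]3C/C=C\C[C@H](c4ccc5ccccc5c4)OC(=O)C[C@@H]2O3)cc1` returns only a limit, > 100000 nM, and not a number. Compound 2 therefore sits at the stronger end of the numbers shown, level with compound 1 and well clear of that limit.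

The next structure is compound 4 `O=C1C[C@@H]2O[C@@H](C=C[C@@H]2O)C/C=C\C[C@H](c2ccc(F)cc2)O1`, which differs from compound 2 by hydrogen in place of 4-methoxybenzyl on an oxygen on a saturated carbon. In words, hydrogen stands in place of 4-methoxybenzyl on an oxygen on a saturated carbon, turning (4-methoxybenzyl)oxy into hydroxy.

Among the measured compounds shown here, only one single-place step has been measured, an at least 21-fold higher number from compound 2 to compound 3 (1.32 log units; beyond the scatter), and it is large. That change lies elsewhere, with naphthalen-2-yl in place of 4-fluorophenyl on a saturated ring carbon, so it says nothing direct about this oxygen. It does show that one change can move the number sharply, which argues for a wide range here. A modest move toward weaker inhibition seems the most likely outcome, since a whole group is lost. The expected step is a 2.1-fold higher number from compound 2 to compound 4 (0.32 log units; beyond the scatter). For compound 4 the estimated value is 10000 nM, with an expected range from 2500 nM to 50000 nM.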

Compound 4, half-maximal inhibitory concentration: 20800 nM
Compound 4: the middle estimate sits 2.1-fold (0.32 log units) below what was measured; the range from low to high includes it.
By their numbers in this assay, from the lowest: compounds 2 and 1 (each within the scatter of the next); then compound 4. At a limit, above all of these: compound 3.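

Among the compounds shown here, this is the first measured change at this oxygen: with the 4-fluorophenyl group held fixed, turning (4-methoxybenzyl)oxy into hydroxy gives a 4.4-fold higher number from compound 2 to compound 4 (0.64 log units; beyond the scatter) in this assay, so the group on this oxygen does affect the read-out, though it is not needed for a measurable value. This step is smaller than the swap of 4-fluorophenyl for naphthalen-2-yl, which gives an at least 21-fold higher number from compound 2 to compound 3 (1.32 log units; beyond the scatter). Compound 3 gives only a limit and not a number: the limit of > 100000 nM in this assay, at which 1 of the 4 values shown sits.

On these data alone, with the 4-fluorophenyl group in place, only 4-methoxybenzyl and hydrogen are compared on this oxygen, so it remains open whether the weaker inhibition of compound 4 reflects the loss of the aromatic ring, the methoxy group or the whole substituent. Compound 1 carries an ethoxy group here but also differs in its 4-chlorophenyl group, so it cannot settle this, and a plain benzyl group, a methyl group or a longer chain ending in an amine on this oxygen would be needed to separate these possibilities.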